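A few compounds are considered here, and "the series" means these few. Any claim that something is new, unique, unknown or untested is made for them only; others in the source may bear on it.

Measured so far:
compound 1 `Cc1nc(-c2ccccc2)c(C(=O)N2CCN(c3cccc(Cl)c3Cl)CC2)o1`, 133 nM;
compound 2 `COc1cc(OC)cc(N2CCN(C(=O)c3oc(C)nc3-c3ccc(F)cc3)CC2)c1`, 38.5 nM;
compound 3 `Cc1nc(-c2ccc(F)cc2)c(C(=O)N2CCN(c3ccc(Cl)cc3)CC2)o1`, "not active" (no number reported), reported with no number.

In a functional assay on HL-60 cells (Homo sapiens) for inhibition, read by MTT assay, with a stated time of 72 h (a lower number here means a stronger inhibitor, a higher number a weaker inhibitor), compound 1 gives 133 nM, the higher of the two numbers; compound 2, with 38.5 nM, gives a lower number, and the gap lies beyond the scatter. Compound 4 `C=C(C)c1ccc(N2CCN(C(=O)c3oc(C)nc3-c3ccccc3)CC2)cc1` shares the core of compound 1 but differs in one place: 4-(1-methylethenyl)phenyl in place of 2,3-dichlorophenyl on an amine nitrogen in a ring. For the measured compounds named here, no measured pair shows this exact change, so the direction is uncertain; compound 3, reported as not active, carries a single chlorine on that ring and offers some caution. The step from compound 1 to compound 4 is expected to be a modest weakening, a 2.3-fold higher number from compound 1 to compound 4 (0.35 log units; beyond the scatter). Compound 4 is estimated at 300 nM, within 60 nM to 2000 nM.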

Compound 4, half-maximal inhibitory concentration: "not active" (no number reported)
The entry for compound 4 holds no number, so the estimate cannot be set against anything.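

Compound 4 is reported as not active in this assay, without a number, so no step from compound 1 can be read, and no available evidence explains this result. From the compounds shown here alone, how much 4-(1-methylethenyl)phenyl in place of 2,3-dichlorophenyl changes the number remains open.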